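Dropping the Aryl Methyl From a Sub-Nanomolar Sulfonamide

A few compounds are considered here, and "the series" means these few. Any claim that something is new, unique, unknown or untested is made for them only; others in the source may bear on it.

Compound 1 `COc1cc(C(=O)NS(=O)(=O)c2ccccc2C)ccc1Cc1cn(C)c2ccc(NC(=O)NC3CCCC3)cc12` gives 1.4 nM in an assay on lung parenchyma for displacement of a labelled ligand from cysteinyl leukotriene receptor 1 (Cavia porcellus) (a lower number here means a stronger inhibitor, a higher number a weaker inhibitor), and compound 2 `COc1cc(C(=O)NS(=O)(=O)c2ccccc2C)ccc1Cc1cn(C)c2ccc(NC(=O)CC3CCCC3)cc12` gives 0.5 nM in this assay. After the step of a 2.8-fold lower number from compound 1 to compound 2 (0.45 log units; beyond the scatter), compound 2 holds the lowest of the two numbers. Compound 3 `COc1cc(C(=O)NS(=O)(=O)c2ccccc2)ccc1Cc1cn(C)c2ccc(NC(=O)CC3CCCC3)cc12` differs from compound 2 by hydrogen in place of methyl on an aromatic carbon. For the measured compounds named here, no measured step touches this part of the shared core; the only step seen concerns cyclopentylmethyl in place of cyclopentylamino on a carbonyl carbon, so it offers no direct guide. Compound 3 is therefore expected to show a step of a 1.6-fold higher number from compound 2 to compound 3 (0.20 log units; within the scatter), not clearly beyond the scatter. Compound 3 is estimated at 0.8 nM, in a range from 0.3 nM to 2 nM.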

Compound 3, inhibition constant: 0.3 nM
Compound 3: the middle estimate sits 2.7-fold (0.43 log units) above what was measured; low and high end bracket the measured number.
By their numbers in this assay, from the lowest: compounds 3 and 2 (each within the scatter of the next); then compound 1.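

Going from 2-methylphenyl to phenyl gives a 1.7-fold lower number from compound 2 to compound 3 (0.22 log units; within the scatter) in this assay and is the first change seen on this part of the shared core. The methyl can therefore go without a shift beyond the scatter, at least alongside the cyclopentylmethyl carbonyl group of compound 2. Nothing available explains this result.

As far as these compounds go, whether a larger group such as ethyl, methoxy or a carboxylic acid would be tolerated on this aromatic carbon stays open. So does whether the same removal would read alike with the cyclopentylamino group of compound 1.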